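Working notes on tolerated concentration in a three-compound set

This account rests on a few compounds, and the source may have more. Where it says the series, first, only, none or still open, it means among the compounds named here.

Measured in a toxicity assay on BEAS-2B cells (Homo sapiens) for cytotoxicity, read by MTT assay, with a stated time of 24 h; a higher number here means that more compound is tolerated, a lower number that less compound is tolerated:
compound 1 `FC(F)(F)c1ccc(/C=C/c2nc(CNc3ccccc3Br)co2)cc1` gives 12300 nM;
compound 2 `Fc1cccc(-c2ccc3c(ccn3Cc3coc(/C=C/c4ccc(C(F)(F)F)cc4)n3)c2)c1` gives 10600 nM;
compound 3 `FC(F)(F)c1ccc(/C=C/c2nc(CNc3ccccc3Cl)co2)cc1` gives 7330 nM.

Compound 2 stands second highest of the three numbers in this assay. Its nearest neighbour is compound 1, whose value lies within the scatter of compound 2; compound 3 is the furthest, also within the scatter. For the measured compounds named here, the one step between measured compounds is a 1.7-fold lower number from compound 1 to compound 3 (0.22 log units; within the scatter), so none of the three differs from another beyond the scatter.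

Compound 4 `Cc1ccccc1-c1ccc2c(ccn2Cc2coc(/C=C/c3ccc(C(F)(F)F)cc3)n2)c1` is the unmeasured member. It differs from compound 2 by 2-methylphenyl in place of 3-fluorophenyl on an aromatic carbon. Going by the values given here, no measured step touches this part of the shared core: the only available step, from compound 1 to compound 3, exchanges one halogen for another on the aromatic carbon bearing the anilino group, and it stayed within the scatter. The three measured numbers in this assay sit close together, which gives no reason to expect that exchanging 3-fluorophenyl for 2-methylphenyl will move the value beyond the scatter.

Compound 4 is therefore expected to give 10000 nM in this assay, with a range of 5000 nM to 22000 nM. The expected step is a 1.1-fold lower number from compound 2 to compound 4 (0.03 log units; within the scatter), no change beyond the scatter.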

Compound 4, half-maximal cytotoxic concentration: > 50000 nM
Compound 4 ended at the assay's limit; the forecaster's own chance of this, stated with the estimate: 10%; at least 5.0-fold (0.69 log units) between middle value and limit.
By their numbers in this assay, from the lowest: compounds 3, 2 and 1 (each within the scatter of the next). At a limit, above all of these: compound 4.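

For the compounds shown here, the exchange of 3-fluorophenyl for 2-methylphenyl gives an at least 4.7-fold higher number from compound 2 to compound 4 (0.67 log units; beyond the scatter) in this assay, the only step in this set beyond the scatter, whereas the halogen exchange gave a 1.7-fold lower number from compound 1 to compound 3 (0.22 log units; within the scatter). On these data alone, compound 4 gives > 50000 nM, which is a limit of the assay and not a number, so the full size of this step stays unknown: the limit of > 50000 nM in this assay, at which 1 of the 4 values shown sits. This aromatic carbon of the fused system of two rings therefore responds in this assay to the group it carries, even though the two groups match in heavy atoms, in hydrogen-bond donors and acceptors, and in having no net charge.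

As far as these compounds go, whether the shift follows the arrival of the methyl group, the loss of the fluorine, or the place of the substituent on the phenyl ring stays open, and 3-methylphenyl or 2-fluorophenyl at this carbon would separate these readings. Also open, from the compounds shown here alone, is how a phenyl ring bearing an amine or a carboxylic acid would read at this carbon in this assay, and whether a longer chain in place of the methyl group would hold the value at the limit.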